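Trichlorophenyl ether on the shared core: toxicity estimate

A few compounds are considered here, and "the series" means these few. Any claim that something is new, unique, unknown or untested is made for them only; others in the source may bear on it.

Compound 1 `N#Cc1ccc(Nc2nc(Oc3ccc(F)cc3)c3ccccc3n2)cc1` gives in an ADME assay on MT4 cells (Homo sapiens) for cytotoxicity, read by MTT assay, with a stated time of 4 days (on this read-out lower numbers stand for higher toxicity in this test and higher numbers for lower toxicity in this test), a value of > 351000 nM, which is a limit of the assay.
Compound 2 `COc1cc(C#N)ccc1Oc1nc(Nc2ccc(C#N)cc2)nc2ccccc12` gives in this assay >= 140000 nM, also a limit of the assay.
Compound 3 `COc1cc(C#N)cc(Cl)c1Oc1nc(Nc2ccc(C#N)cc2)nc2ccccc12` gives in this assay 220000 nM.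

Compound 2 stands only at a limit, and one further value is a limit as well. Compound 4 `N#Cc1ccc(Nc2nc(Oc3c(Cl)cc(Cl)cc3Cl)c3ccccc3n2)cc1` differs from compound 2 by 2,4,6-trichlorophenyl in place of 4-cyano-2-methoxyphenyl on an oxygen on an aromatic ring. Within the data shown here, two measured steps touch this region: a step that the two limits leave unreadable from compound 1 to compound 2 and a step that the limit leaves unreadable from compound 2 to compound 3. Neither has a readable size because the limit of > 351000 nM in this assay, at which 1 of the 3 values shown sits, and the limit of >= 140000 nM in this assay, at which 1 of the 3 values shown sits, cap those values, so no direction can be expected beyond the scatter. Compound 4 is therefore estimated at 150000 nM, between 40000 nM and 400000 nM. That estimate means an expected step that the limit leaves unreadable from compound 2 to compound 4, and the result may again be a limit.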

Compound 4, half-maximal cytotoxic concentration: 56000 nM
Compound 4: middle estimate off by 2.7-fold (0.43 log units), on the high side; the range from low to high includes it.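

This position now shows a readable change in this assay: 2,4,6-trichlorophenyl on the oxygen gives an at least 2.5-fold lower number from compound 2 to compound 4 (0.39 log units; beyond the scatter), and it also gives an at least 6.2-fold lower number from compound 1 to compound 4 (0.79 log units; beyond the scatter). On this read-out a lower number means higher toxicity in this test, so this group reads as more toxic than 4-cyano-2-methoxyphenyl and 4-fluorophenyl. The full size of the second step stays open because compound 1 sits at a limit: the limit of > 351000 nM in this assay, at which 1 of the 4 values shown sits.

The compounds shown do not separate the effect of the three chlorines from the loss of the earlier groups. As far as these compounds go, how a ring carrying an amine or a carboxylic acid would read here remains open.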